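A few compounds are considered here, and "the series" means these few. Any claim that something is new, unique, unknown or untested is made for them only; others in the source may bear on it.

Measured so far in a functional assay on SK-OV-3 cells (Homo sapiens) for inhibition, read by CCK-8 assay, with a stated time of 70 h; a higher number here means a weaker inhibitor, a lower number a stronger inhibitor:
Compound 1, `Clc1ccc(COc2ccc(OCCOCCNC3CCCCC3)cc2)cc1`, gives 2650 nM.
Compound 2, `Clc1ccc(COc2ccc(OCCOCCNC3CCCC3)cc2)cc1`, gives 7670 nM.
Compound 3, `c1ccc(COc2ccc(COc3ccc(OCCOCCNC4CCCC4)cc3)cc2)cc1`, gives 10000 nM.

Compound 2 stands second highest of the three numbers in this assay. Its nearest neighbour is compound 3, reached by a 1.3-fold higher number from compound 2 to compound 3 (0.12 log units; within the scatter), a step that stays within the scatter; its furthest is compound 1, from which it is reached by a 2.9-fold higher number from compound 1 to compound 2 (0.46 log units; beyond the scatter), a step beyond the scatter.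

The unmeasured compound 4, `COC(=O)c1ccccc1COc1ccc(OCCOCCNC2CCCC2)cc1`, differs from compound 2 in one place: 2-(methoxycarbonyl)phenyl in place of 4-chlorophenyl on a saturated chain carbon bound to an oxygen on an aromatic ring.

Within the data shown here, only one measured step touches the same place as this change. It is a 1.3-fold higher number from compound 2 to compound 3 (0.12 log units; within the scatter), in which the chloro on the aromatic carbon was replaced by benzyloxy and the number in this assay moved by less than the scatter. Among the measured compounds shown here, the change to compound 4 again removes the chloro from that ring, while the exit of 4-chlorophenyl and the entry of 2-(methoxycarbonyl)phenyl has no direct precedent among the measured compounds. On that basis the step from compound 2 to compound 4 is expected to be small, if anything towards a higher number, and is estimated as a 1.3-fold higher number from compound 2 to compound 4 (0.12 log units; within the scatter). Compound 4 is therefore expected to give about 10000 nM in this assay, with a range from 4000 nM to 25000 nM.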

Compound 4, half-maximal inhibitory concentration: > 100000 nM
Compound 4 ended at the assay's limit; the forecaster's own chance of this, stated with the estimate: 30%; middle value at least 10-fold (1.00 log units) away from the limit.
By their numbers in this assay, from the lowest: compound 1; then compounds 2 and 3 (each within the scatter of the next). At a limit, above all of these: compound 4.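

In this assay, replacing 4-chlorophenyl with 2-(methoxycarbonyl)phenyl on the saturated chain carbon bound to an oxygen on an aromatic ring gives an at least 13-fold higher number from compound 2 to compound 4 (1.11 log units; beyond the scatter), whereas the earlier change at this ring, with benzyloxy in place of chloro, gave a 1.3-fold higher number from compound 2 to compound 3 (0.12 log units; within the scatter). This place therefore does not accept every replacement of the 4-chlorophenyl group, and the loss of the chloro alone cannot account for the large step, since compound 3 also lacks it and stays within the scatter of compound 2. The result for compound 4 is a limit of the assay and not a number, so the full size of the step remains unknown: the limit of > 100000 nM in this assay, at which 1 of the 4 values shown sits.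

The compounds shown do not separate the effect of the methoxycarbonyl group itself from that of where it sits on the ring, a question that 4-(methoxycarbonyl)phenyl and 2-chlorophenyl would address at this place. They also leave open how a carboxylic acid or a primary amide would behave there, and whether the same change would have a similar result with the cyclohexyl group of compound 1 on the amine nitrogen.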